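A Chlorophenyl Swap After Two Matched Readings

This account rests on a few compounds, and the source may have more. Where it says the series, first, only, none or still open, it means among the compounds named here.

In a functional assay on the whole organism (strain Kunming) with Mus musculus as the target, with a stated time of 0.5 h (on this read-out lower numbers stand for an effect already at smaller amounts and higher numbers for an effect only at larger amounts of compound), compound 2 `COc1cccc(/C=C/C(=O)OC/C=C/c2cc(OC)c(OC)cc2OC)c1` gives 190 umol/kg and compound 1 `COc1cc(OC)c(OC)cc1/C=C/COC(=O)/C=C/c1cccc(Br)c1` gives 175 umol/kg, so the two lie within the scatter of each other. Compound 3 `COc1cc(OC)c(OC)cc1/C=C/COC(=O)/C=C/c1ccc(Cl)cc1` differs from compound 2 by 4-chlorophenyl in place of 3-methoxyphenyl on a double-bonded chain carbon bound to a double-bonded chain carbon. Among the measured compounds shown here, the one measured step that bears on this, a 1.1-fold higher number from compound 1 to compound 2 (0.04 log units; within the scatter) for methoxy in place of bromo on an aromatic carbon, is small, and no measured compound carries 4-chlorophenyl. An expected 1.1-fold lower number from compound 2 to compound 3 (0.02 log units; within the scatter) therefore stays within the scatter, with no direction favoured. For compound 3 the estimated value is 180 umol/kg, with an expected range of 90 umol/kg to 360 umol/kg.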

Compound 3, dose for half-maximal effect: 137 umol/kg
Compound 3: the middle estimate sits 1.3-fold (0.12 log units) above what was measured; measured number inside the range.
By their numbers in this assay, from the lowest: compounds 3, 1 and 2 (each within the scatter of the next).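

In this assay, putting 4-chlorophenyl on a double-bonded chain carbon bound to a double-bonded chain carbon gives a 1.4-fold lower number from compound 2 to compound 3 (0.14 log units; within the scatter) when it replaces 3-methoxyphenyl and a 1.3-fold lower number from compound 1 to compound 3 (0.11 log units; within the scatter) when it replaces 3-bromophenyl. This place thus now spans 3-methoxyphenyl, 3-bromophenyl and 4-chlorophenyl, and none of the three stands apart from the others on this read-out. Nothing available accounts for these numbers. From the compounds shown here alone, whether a phenyl ring bearing an amine or a carboxylic acid would move the number beyond the scatter remains open. So does whether 3-chlorophenyl would read like 4-chlorophenyl.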